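Compound 2 to compound 4: a sulfonyl swap

This account rests on a few compounds, and the source may have more. Where it says the series, first, only, none or still open, it means among the compounds named here.

Of the compounds shown here, three have been tested in a functional assay on Huh-7 cells (Homo sapiens) for cytotoxicity, read by MTT assay, with a stated time of 72 h; on this read-out lower numbers stand for higher toxicity in this test and higher numbers for lower toxicity in this test. Compound 1 `CS(=O)(=O)N1CCC2(CC1)OOC1(CCN(S(C)(=O)=O)CC1)OO2` gives > 100 ug/mL, which is a limit of the test. Compound 3 `O=S(=O)(Cc1ccccc1)N1CCC2(CC1)OOC1(CCCC1)OO2` gives > 100 ug/mL, also a limit. Compound 2 `O=S(=O)(CCCCl)N1CCC2(CC1)OOC1(CCCCCC1)OO2` gives > 100 ug/mL, again only a limit. Compound 4 `O=S(=O)(c1ccc(Br)cc1F)N1CCC2(CC1)OOC1(CCCCCC1)OO2` differs from compound 2 in one place: 4-bromo-2-fluorophenyl in place of 3-chloropropyl on a sulfonyl sulfur. In words, 4-bromo-2-fluorophenyl stands in place of 3-chloropropyl on a sulfonyl sulfur. Within the data shown here, no measured pair shows the effect of such a change. The expected a number no higher from compound 2 to compound 4 (the limit leaves the size open) is no larger than the usual scatter, in either direction. That expectation rests on (the limit of > 100 ug/mL in this assay, at which 3 of the 3 values shown sit). For compound 4 the estimated value is 100 ug/mL, with an expected range from 45 ug/mL to 200 ug/mL.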

Compound 4, half-maximal cytotoxic concentration: > 100 ug/mL
Compound 4 ended at the assay's limit; the forecaster's own chance of this, stated with the estimate: 65%; the middle value lies on the limit itself.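

Compound 2 and compound 4 each give only a limit, so no step can be read between them. The compounds shown leave open whether any change on the sulfonyl sulfur alters toxicity in this assay.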